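The compounds below may be only part of what the source reports. "The series", "measured", "known", "first", "only" and "open" are said of these compounds alone.

Three measured compounds frame the question. Compound 1 `CC1(C)CC(C)(C)c2cc(NC(=O)Nc3ccc(OC(F)(F)F)cc3)ccc2O1` gives 4560 nM in a functional assay on A2780 cells (Homo sapiens) for inhibition, with a stated time of 72 h; a lower number here means a stronger inhibitor, a higher number a weaker inhibitor. Compound 2 `CC1(C)CCOc2ccc(NC(=O)Nc3ccc([N+](=O)[O-])cc3)cc21` gives 6700 nM in this assay, the highest of the three numbers. Compound 3 `CC1(C)CC(C)(C)c2cc(NC(=S)Nc3ccc([N+](=O)[O-])cc3)ccc2S1` gives 3170 nM in this assay. Against compound 2, compound 1 lies within the usual scatter, while compound 3 sits beyond it. Compound 4 `CC1(C)CCOc2ccc(NC(=O)Nc3ccc(OC(F)(F)F)cc3)cc21` differs from compound 2 in one place: trifluoromethoxy in place of nitro on an aromatic carbon. Among the compounds with values here, no pair of measured compounds isolates this change, so no measured step guides the expectation. Compound 1 already carries the trifluoromethoxy group on a different core, and its 4560 nM lies close to compound 2, so the step expected in this assay is small, in either direction or none beyond the scatter. The estimate means a step of a 1.3-fold lower number from compound 2 to compound 4 (0.13 log units; within the scatter) within the scatter. Compound 4 is expected to give 5000 nM, between 2500 nM and 10000 nM.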

Compound 4, half-maximal inhibitory concentration: 3500 nM
Beside the measured number, compound 4's estimate is 1.4-fold (0.15 log units) above it; low and high end bracket the measured number.
By their numbers in this assay, from the lowest: compounds 3, 4, 1 and 2 (each within the scatter of the next, the first and the last beyond it).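

Swapping nitro for trifluoromethoxy on the aromatic carbon para to a large group gives a 1.9-fold lower number from compound 2 to compound 4 (0.28 log units; within the scatter) in this assay. This first direct comparison at this position shows that, on this shared core, the two groups cannot be told apart in this measurement, even though they differ in size and atom makeup. Nothing available offers an explanation for this result. From the compounds shown here alone, what an amine, a carboxylic acid or a longer chain would do at this position remains open.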